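This account rests on a few compounds, and the source may have more. Where it says the series, first, only, none or still open, it means among the compounds named here.

Measured so far:
compound 1 `CNc1nc(NCc2ccc(OC(F)(F)F)cc2)cc(-c2ccccn2)n1` — 13 nM
compound 2 `c1ccc(-c2cc(NCC3CC3)ncn2)nc1` — 22000 nM
compound 3 `CNc1nc(NCc2ccc(S(C)(=O)=O)cc2)cc(-c2ccccn2)n1` — 36 nM

Compound 3 stands second of the three numbers in a functional assay on HEK293 cells for agonist activity at G-protein coupled receptor 39 (Homo sapiens), read by inositol phosphate accumulation; a higher number here means that more compound is needed for the effect, a lower number that less compound is needed. Its nearest neighbour is compound 1, which gives 13 nM in this assay; the step of a 2.8-fold higher number from compound 1 to compound 3 (0.44 log units; beyond the scatter) is the only one in the set that changes a single group. Compound 2 differs from compound 3 in several places. In this assay compound 2 gives 22000 nM and lies far from the other two.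

Compound 4 `CNc1nc(NCc2ccc(Cl)cc2)cc(-c2ccccn2)n1` is not yet measured. It differs from compound 3 in one place: chloro in place of methylsulfonyl on an aromatic carbon.

The step from compound 1 to compound 3 is the one that bears on this change, since it also swaps the group on the same aromatic carbon; it moved the number modestly, beyond the scatter. Compound 2 is not informative here, as it alters other parts of the structure. The chloro group, like trifluoromethoxy, carries no hydrogen-bond acceptor in the counts, so the expectation for compound 4 is a modest step back toward the number of compound 1, roughly a 1.8-fold lower number from compound 3 to compound 4 (0.26 log units; within the scatter). Compound 4 is therefore estimated at 20 nM, with a range from 8 nM to 50 nM.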

Compound 4, half-maximal effective concentration: 15 nM
Beside the measured number, compound 4's estimate is 1.3-fold (0.12 log units) above it, within the range that was stated.
By their numbers in this assay, from the lowest: compounds 1 and 4 (each within the scatter of the next); then compound 3; then compound 2.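

In this assay, chloro in place of methylsulfonyl on the aromatic carbon para to a large group gives a 2.4-fold lower number from compound 3 to compound 4 (0.38 log units; beyond the scatter), so the gap around compound 3 is now seen against a second group and not against trifluoromethoxy alone. Chloro in place of trifluoromethoxy at the same carbon gives a 1.2-fold higher number from compound 1 to compound 4 (0.06 log units; within the scatter), which leaves the two groups unresolved in this assay and shows that a single heavy atom at this position gives a number level with that of the larger trifluoromethoxy group. Among these three groups, methylsulfonyl, the one with hydrogen-bond acceptors in the counts, stands apart, but the data cannot separate those acceptors from its other differences, and no measurement shown gives a reason for either step.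

From the compounds shown here alone, whether an amine, a carboxylic acid or a longer chain on this aromatic carbon stays level with chloro and trifluoromethoxy or moves towards methylsulfonyl remains open. Going by these compounds, compound 2 differs in several places, so the separate contribution of each of those changes to its much higher number also remains open.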